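The compounds below may be only part of what the source reports. "The series", "measured", "known", "first", "only" and "open" are said of these compounds alone.

Working notes on the series. Of the compounds shown here, three on a shared core have been measured in a functional assay on HL-60 cells (Homo sapiens) for antiproliferative activity, with a stated time of 24 h; on this read-out higher numbers stand for weaker inhibition and lower numbers for stronger inhibition. Compound 1 `NC(=O)c1c(NC(=O)c2ccc(C(F)(F)F)cc2)sc2c1CCN(Cc1ccc(Cl)cc1)C2` carries a 4-chlorobenzyl group on the ring amine; in this assay compound 1 reports only a limit, > 50000 nM. Compound 3 `NC(=O)c1c(NC(=O)c2ccc(C(F)(F)F)cc2)sc2c1CCN(C(=S)Nc1ccccc1Cl)C2` carries instead a thiourea bearing a 2-chlorophenyl group; compound 3 gives 36100 nM, the highest of the two numbers in hand. For the measured compounds named here, the change an at least 1.3-fold lower number from compound 1 to compound 3 (0.14 log units; that floor lies within the scatter) is the only single-point step available, and its floor lies within the scatter, so it says little about direction; the one limit value is noted under (the limit of > 50000 nM in this assay, at which 1 of the 3 values shown sits). Compound 2 `NC(=O)c1c(NC(=O)c2ccccc2Cl)sc2c1CCN(C(=S)Nc1ccc(C(F)(F)F)cc1)C2` differs from compound 3 in two places at once, so no single step can be read from the pair; compound 2 gives 7590 nM.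

Compound 4 `NC(=O)c1c(NC(=O)c2ccc(C(F)(F)F)cc2)sc2c1CCN(C(=S)Nc1ccc(C(F)(F)F)cc1)C2` is the next candidate. Relative to compound 3 the change is 4-(trifluoromethyl)phenyl in place of 2-chlorophenyl on an amide-type nitrogen. Going by the values given here, no measured step bears directly on this exchange. The 4-(trifluoromethyl)phenyl thiourea of compound 4 is shared by compound 2, which sits at 7590 nM, and this is the only point of orientation. The number for compound 4 is expected to move by a 2.4-fold lower number from compound 3 to compound 4 (0.38 log units; beyond the scatter), toward the lower side. The estimate for compound 4 is 15000 nM, with a range from 4000 nM to 50000 nM.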

Compound 4, half-maximal inhibitory concentration: 5520 nM
Estimate against measurement, compound 4: 2.7-fold (0.43 log units) above; the range from low to high includes it.
By their numbers in this assay, from the lowest: compounds 4 and 2 (each within the scatter of the next); then compound 3. At a limit, above all of these: compound 1.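

For the compounds shown here, the step on the amide-type nitrogen is the first reading of an aryl exchange on the thiourea: in this assay, 4-(trifluoromethyl)phenyl in place of 2-chlorophenyl gives a 6.5-fold lower number from compound 3 to compound 4 (0.82 log units; beyond the scatter). The same exchange on the carbonyl carbon, with the 4-(trifluoromethyl)phenyl thiourea held constant, gives a 1.4-fold lower number from compound 2 to compound 4 (0.14 log units; within the scatter), so among compounds 2, 3 and 4 the exchange registers beyond the scatter only on the amide-type nitrogen, and the aryl group on the carbonyl carbon shows no separable effect in this pair. Nothing measured here accounts for the step on the amide-type nitrogen.

The exchange on the amide-type nitrogen alters both the substituent and where it sits on the phenyl ring, so the compounds shown cannot separate the loss of 2-chlorophenyl from the gain of 4-(trifluoromethyl)phenyl. Also open, from the compounds shown here alone, are how a 4-chlorophenyl group, an unsubstituted phenyl or a phenyl ring bearing a carboxylic acid would read on that nitrogen, and whether the result on the carbonyl carbon holds when the thiourea carries 2-chlorophenyl.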